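A Methyl Added to a Weakly Active Stomach Cancer Inhibitor

The source may hold more compounds than are shown below. What is called first, only, known or untested is meant among the compounds shown, and "the series" means these compounds.

compound 1 `Cc1cc(C)nc(Oc2ccc(NC(=O)Nc3ccccc3)cc2)n1`: "not determined" (no result reported)
compound 2 `Cc1cc(C)nc(Oc2ccc(NC(=O)Nc3ccc(OC(F)(F)F)cc3)cc2)n1`: > 50000 nM
compound 3 `Cc1cc(C)nc(Sc2ccc(NC(=O)Nc3ccccc3)cc2)n1`: 40100 nM

The compounds were tested in a functional assay on MGC-803 cells (Homo sapiens) for cytotoxicity, read by MTT assay, with a stated time of 3 days (on this read-out lower numbers stand for stronger inhibition and higher numbers for weaker inhibition), which reads how strongly each one holds back the growth of a human stomach cancer cell line. Compound 1 has "not determined" (no result reported). Compound 2 is reported only as a limit of the assay, > 50000 nM, and not as a number (the limit of > 50000 nM in this assay, at which 1 of the 3 values shown sits). Compound 3 gives 40100 nM. Among the compounds with values here, compound 3 thus stands as the single fixed number in this small set, with one limit beside it and one entry without any number.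

Compound 4 `Cc1cccc(NC(=O)Nc2ccc(Sc3nc(C)cc(C)n3)cc2)c1` differs from compound 3 by methyl in place of hydrogen on an aromatic carbon. Within the data shown here, no pair of measured compounds differs at that site, so no measured step is available to lean on. On that basis the change is expected to move the value, if at all, by no more than the usual scatter, in no preferred direction. The step from compound 3 to compound 4 is estimated at a 1.1-fold lower number from compound 3 to compound 4 (0.02 log units; within the scatter). Compound 4 is therefore expected to give 38000 nM, most likely between 13000 nM and 110000 nM.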

Compound 4, half-maximal inhibitory concentration: 25300 nM
For compound 4 the middle estimate is 1.5-fold (0.18 log units) above the measured one, within the range that was stated.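

Within the data shown here, the change from phenyl to 3-methylphenyl provides the first measured step in this set, and in this assay it reads as a 1.6-fold lower number from compound 3 to compound 4 (0.20 log units; within the scatter). At this place, an aromatic carbon meta to a large group, compound 3 and compound 4 therefore cannot be told apart on this read-out, so this single methyl gives no clear sign that the site matters for activity against these cells. Nothing in the available information bears on a cause for this small step.

On these data alone, it remains open whether a different group at the same place, such as an amine, a carboxylic acid or a longer chain, would give a value clearly separate from that of compound 3. Also open, as far as these compounds go, is what a methyl would do on any other carbon of that ring.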